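The compounds below may be only part of what the source reports. "The series", "measured", "known", "first", "only" and "open" are said of these compounds alone.

Compound 1 `OC[C@H](NC[C@H]1NC[C@H](O)[C@@H]1O)c1ccc(-c2ccccc2)cc1`: > 200000 nM.
Compound 2 `C=CCOc1ccc([C@H](CO)NC[C@H]2NC[C@H](O)[C@@H]2O)cc1`: > 200000 nM.

In a functional assay on SK-BR-3 cells (Homo sapiens) for cytotoxicity, read by colorimetric assay, with a stated time of 72 h (on this read-out lower numbers stand for stronger inhibition and higher numbers for weaker inhibition), compound 1 gives only a limit, > 200000 nM. In this assay compound 2 likewise gives only a limit, > 200000 nM. Compound 2 thus stands at the limit of > 200000 nM in this assay, at which 2 of the 2 values shown sit, and the step that the two limits leave unreadable from compound 1 to compound 2 cannot be read. Compound 3 `OC[C@H](NC[C@H]1NC[C@H](O)[C@@H]1O)c1ccc(OCc2ccccc2)cc1` differs from compound 2 by phenyl in place of vinyl on a saturated chain carbon bound to an oxygen on an aromatic ring. Among the compounds with values here, no measured step bears on this change, so no shift beyond the scatter is expected in this assay. The step that the limit leaves unreadable from compound 2 to compound 3 is expected to be negligible. Compound 3 is expected to give about 250000 nM, between 50000 nM and 1000000 nM, most probably again as a limit.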

Compound 3, half-maximal inhibitory concentration: "not active" (no number reported)
Compound 3: no number reported; the estimate stays without a comparison.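

Within the data shown here, compound 3 is reported only as "not active", without a number, so no step from compound 2 to compound 3 can be read. The compounds shown leave open whether the group on the aromatic ring affects the read-out in this assay at all.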